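Swapping the amine linker for a methylene at the piperidine

The source may report more compounds than this note shows. Statements on the series, on what has been measured and on what is new or still open speak of the compounds shown alone.

Measured compounds:
Compound 1, `Cc1cc(Cl)cc(-c2ccnc3cc(CN4C(=O)C5C(C4=O)C5(C)C)sc23)c1C[C@@H]1CNCCO1`: 25 nM
Compound 2, `Cc1cc(Cl)cc(-c2ccnc3cc(CN4C(=O)CCC4=O)sc23)c1O[C@@H]1CCNC[C@@H]1C`: 150 nM
Compound 3, `Cc1cc(Cl)cc(-c2ccnc3cc(CN4C(=O)C5C(C4=O)C5(C)C)sc23)c1NC1CCCNC1`: 33 nM

In an assay on RKO cells for inhibition of ubiquitin carboxyl-terminal hydrolase 7 (Homo sapiens), read by a luciferase reporter, with a stated time of 18 h (on this read-out higher numbers stand for an effect only at larger amounts of compound and lower numbers for an effect already at smaller amounts), compound 3 gives 33 nM, the second highest of the three numbers. Its nearest neighbour is compound 1, and the difference a 1.3-fold higher number from compound 1 to compound 3 (0.12 log units; within the scatter) lies within the scatter. For the measured compounds named here, compound 2 is the furthest away, with a number well above that of compound 3; no single-change step links these two.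

Compound 4, `Cc1cc(Cl)cc(-c2ccnc3cc(CN4C(=O)C5C(C4=O)C5(C)C)sc23)c1CC1CCCNC1`, differs from compound 3 in one place: (piperidin-3-yl)methyl in place of (piperidin-3-yl)amino on an aromatic carbon. Going by the values given here, the only measured step at this position is the one from compound 1 to compound 3, a 1.3-fold higher number from compound 1 to compound 3 (0.12 log units; within the scatter), which stayed within the scatter although the group attached to the aromatic carbon changed considerably. On that basis the account expects that the change in compound 4 will likewise produce no step beyond the scatter in this assay, with the step of a 1.1-fold lower number from compound 3 to compound 4 (0.04 log units; within the scatter) estimated as small and of uncertain direction. Compound 4 is therefore estimated to give 30 nM in this assay, with a likely range from 12 nM to 80 nM.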

Compound 4, half-maximal effective concentration: 130 nM
Beside the measured number, compound 4's estimate is 4.3-fold (0.64 log units) below it; the measured number lies above the stated range.
By their numbers in this assay, from the lowest: compounds 1 and 3 (each within the scatter of the next); then compounds 4 and 2 (each within the scatter of the next).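

In this assay, the piperidin-3-yl ring does not tolerate every link to the aromatic carbon: (piperidin-3-yl)methyl in place of (piperidin-3-yl)amino gives a 3.9-fold higher number from compound 3 to compound 4 (0.60 log units; beyond the scatter). With the carbon link kept, the ring also counts, since piperidin-3-yl in place of morpholin-2-yl gives a 5.2-fold higher number from compound 1 to compound 4 (0.72 log units; beyond the scatter). The earlier step of a 1.3-fold higher number from compound 1 to compound 3 (0.12 log units; within the scatter) therefore changed both ring and link without a shift beyond the scatter, yet each change alone, on these compounds, does produce one. Nothing available bears on the cause of these steps.

As far as these compounds go, it remains open whether ring and link act independently, which a (morpholin-2-yl)amino group on the same aromatic carbon would test. From the compounds shown here alone, how a sulfur atom as the link would rank is also open.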